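Cyclopropyl for ethyl on the amide carbonyl: a volume comparison

The source may hold more compounds than are shown below. What is called first, only, known or untested is meant among the compounds shown, and "the series" means these compounds.

Three compounds sharing one bicyclic core were measured in an ADME assay (Rattus norvegicus, strain Wistar Han) for pharmacokinetics; on this read-out lower numbers stand for narrower distribution and higher numbers for wider distribution into tissues. Compound 1 `CCn1c(-c2cnc(C)nc2)nc2c(O[C@H]3CCN(C(=O)C4CC4)C3)ncnc21` gives 2.8 L/kg, compound 2 `CCC(=O)N1CC[C@H](Oc2ncnc3c2nc(-c2cnc(C)nc2)n3CC)C1` gives 2.4 L/kg, and compound 3 `CCC(=O)N1CC[C@H](Nc2ncnc3c2nc(-c2cnc(C)nc2)n3CC)C1` gives 3.6 L/kg. Compound 2 and compound 1 differ by cyclopropyl in place of ethyl on a carbonyl carbon, and this gave a 1.2-fold higher number from compound 2 to compound 1 (0.07 log units; within the scatter). The difference between the core of compound 2 and the core of compound 3 is not broken down here; their two values in this assay lie within the usual scatter of each other, as do the values of compound 3 and compound 1.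

Compound 4 `CCn1c(-c2cnc(C)nc2)nc2c(N[C@H]3CCN(C(=O)C4CC4)C3)ncnc21` has not yet been measured. It stands to compound 3 as compound 1 stands to compound 2: the difference is cyclopropyl in place of ethyl on a carbonyl carbon, the same change at the same place. Because the earlier step of a 1.2-fold higher number from compound 2 to compound 1 (0.07 log units; within the scatter) stayed within the scatter, the step of a 1.2-fold higher number from compound 3 to compound 4 (0.08 log units; within the scatter) is expected to be small as well. Compound 4 is therefore estimated at 4.3 L/kg, with a likely range from 2.6 L/kg to 7 L/kg.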

Compound 4, volume of distribution: 6.3 L/kg
Compound 4: middle estimate off by 1.5-fold (0.17 log units), on the low side; the measured number falls inside the stated range.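

In this assay, cyclopropyl in place of ethyl on a carbonyl carbon gave a 1.8-fold higher number from compound 3 to compound 4 (0.24 log units; within the scatter). Set beside the same change on the other core, the new step does not stand apart from the earlier one: the same change on two cores in this assay, a 1.2-fold higher number (0.07 log units; within the scatter) from compound 2 to compound 1 and a 1.8-fold higher number (0.24 log units; within the scatter) from compound 3 to compound 4, 1.5-fold (0.18 log units) apart, within the scatter of two such steps This shows that, across these two pairs, propanoyl to cyclopropylcarbonyl behaved alike on both cores within what this read-out can resolve, but it does not show that the change itself shifts the volume of distribution, since each step lies within the scatter, and two pairs cannot establish a rule for the wider series.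

The compounds shown leave open whether the same holds when the carbonyl carbon carries a longer chain such as butyl, a larger ring such as cyclobutyl, or a group bearing an amine. They also leave open whether the agreement extends to any core beyond these two, or to any read-out other than this assay.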